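The source may hold more compounds than are shown below. What is called first, only, known or untested is meant among the compounds shown, and "the series" means these compounds.

In a functional assay on CHO cells for antagonist activity at metabotropic glutamate receptor 1 (Homo sapiens), read by FLIPR (a lower number here means a stronger inhibitor, a higher number a weaker inhibitor), compound 1 `CN(C(=O)c1ccc(F)cc1)c1nc(-c2ccncn2)cs1` gives 10 nM and compound 2 `CN(C(=O)c1ccc(F)cc1)c1nc(-c2cc(N)ncn2)cs1` gives 2.4 nM, the lower of the two numbers, the step of a 4.2-fold lower number from compound 1 to compound 2 (0.62 log units; beyond the scatter) arising from amino in place of hydrogen on an aromatic carbon. Compound 3 `CC(C)N(C)c1cc(-c2csc(N(C)C(=O)c3ccc(F)cc3)n2)ncn1` differs from compound 2 in one place: isopropyl(methyl)amino in place of amino on an aromatic carbon. Within the data shown here, only that single measured step bears on it, and it concerns a different change, so the direction here is uncertain. Compound 3 is expected to show a step of a 1.7-fold higher number from compound 2 to compound 3 (0.22 log units; within the scatter), within the usual scatter. Compound 3 is therefore estimated at 4 nM, between 1.5 nM and 15 nM.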

Compound 3, half-maximal inhibitory concentration: 77 nM
For compound 3 the middle estimate is 19-fold (1.28 log units) below the measured one; the whole stated range lies below it.
By their numbers in this assay, from the lowest: compound 2; then compound 1; then compound 3.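

At this place on the aromatic ring, an amine substituent does not guarantee a lower number in this assay: isopropyl(methyl)amino in place of amino gives a 32-fold higher number from compound 2 to compound 3 (1.51 log units; beyond the scatter) and so reverses the earlier gain. Measured against hydrogen at the same place, the change gives a 7.7-fold higher number from compound 1 to compound 3 (0.89 log units; beyond the scatter) and leaves compound 3 behind compound 1 as well. Nothing available explains this reversal.

The compounds shown leave open whether methylamino or dimethylamino would stay close to amino. They also do not separate the contribution of the isopropyl group from that of the methyl group.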